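The compounds below may be only part of what the source reports. "The series", "measured", "known", "first", "only" and "open" are said of these compounds alone.

Values in an ADME assay for permeability, using PAMPA, with a stated time of 4 h, at pH 5.5; a lower number here means that the compound crosses the layer more slowly, a higher number that the compound crosses the layer faster:
- compound 1 `NCCCCN(C[C@@H]1Cc2nccnc2CN1)[C@H]1CCCc2cccnc21`: 2 nm/s
- compound 2 `NC/C=C\CN(C[C@H]1Cc2ncccc2CN1)[C@H]1CCCc2cccnc21`: 28 nm/s

Compound 2, at 28 nm/s, holds the higher of the two numbers, and its gap to compound 1 lies beyond the scatter. The next compound is compound 3 `NC/C=C/CN(C[C@H]1Cc2ncccc2CN1)[C@H]1CCCc2cccnc21`, and its change from compound 2 is the two compounds have the same atoms and bonds and differ only in configuration as drawn: 1 of 3 stereo elements differ; a double bond is drawn Z in compound 2 and E in compound 3. Among the measured compounds shown here, no measured pair isolates the geometry of a double bond, so the expectation has little support. The expected 1.1-fold lower number from compound 2 to compound 3 (0.05 log units; within the scatter) is none beyond the scatter in this assay. The estimate for compound 3 is 25 nm/s, with a range of 10 nm/s to 60 nm/s.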

Compound 3, apparent permeability: 2 nm/s
Beside the measured number, compound 3's estimate is 13-fold (1.10 log units) above it, outside the stated range (below it).
By their numbers in this assay, from the lowest: compounds 1 and 3 (each within the scatter of the next); then compound 2.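

In this assay the change of the double bond from Z to E gives a 14-fold lower number from compound 2 to compound 3 (1.15 log units; beyond the scatter). The earlier compounds shown here left the geometry of this chain untested, and this pair shows that it alone can carry a large step. The step can be assigned to the double bond geometry because of one feature of the pair: the fact that compounds 2 and 3 differ only in the configuration as drawn

Open, as far as these compounds go, is how a triple bond or a longer chain at this place would read against the Z and E forms. Also open, from the compounds shown here alone, is whether the same geometry step appears on the core of compound 1.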